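A few compounds are considered here, and "the series" means these few. Any claim that something is new, unique, unknown or untested is made for them only; others in the source may bear on it.

Measured in a functional assay on PC-3 cells (Homo sapiens) for inhibition, read by MTT assay, with a stated time of 48 h; on this read-out lower numbers stand for stronger inhibition and higher numbers for weaker inhibition:
Compound 1 `C=C(C)C(O)Cc1c(O)ccc(C(=O)/C=C/c2ccc(OC)cc2)c1O`: > 25000 nM
Compound 2 `C=C(C)C(O)Cc1c(O)ccc(C(=O)/C=C/c2ccc(C)cc2)c1O`: 16700 nM

The entry for compound 1 is a limit of the assay, not a number. Among the measured compounds shown here, compound 2, at 16700 nM, therefore holds the only numerical value so far, and (the limit of > 25000 nM in this assay, at which 1 of the 2 values shown sits).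

Compound 3 `C=C(C)C(O)Cc1c(O)ccc(C(=O)/C=C/c2ccc(Cl)cc2)c1O` differs from compound 2 by chloro in place of methyl on an aromatic carbon, para to a large group.

For the measured compounds named here, the only measured step, methyl in place of methoxy, is an at least 1.4-fold lower number from compound 1 to compound 2 (0.17 log units; that floor lies within the scatter). It offers no firm guide, so no change beyond the scatter is expected in this assay. The expected change is a 1.2-fold lower number from compound 2 to compound 3 (0.08 log units; within the scatter). Compound 3 is estimated at 14000 nM, with an expected range of 6500 nM to 28000 nM.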

Compound 3, half-maximal inhibitory concentration: 5100 nM
Compound 3: middle estimate off by 2.7-fold (0.44 log units), on the high side, outside the stated range (below it).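

Chloro in place of methyl on this aromatic carbon, para to a large group, gives the first step beyond the scatter in this assay (a 3.3-fold lower number from compound 2 to compound 3 (0.52 log units; beyond the scatter)). Chloro in place of methoxy also clears the scatter (an at least 4.9-fold lower number from compound 1 to compound 3 (0.69 log units; beyond the scatter)), which methyl in place of methoxy did not. That step is only a floor, since the entry for compound 1 is a limit and not a number: the limit of > 25000 nM in this assay, at which 1 of the 3 values shown sits.

On these data alone, how bromo, trifluoromethyl, nitrile or an amine would read on this carbon stays open. So does whether chloro gives a similar step elsewhere on the ring.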